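Amide aryl variation on the flavonol series: compound 4

This account rests on a few compounds, and the source may have more. Where it says the series, first, only, none or still open, it means among the compounds named here.

The series shares one core, in which the aryl on the amide carbonyl is varied. Compound 1 `COc1ccc(C(=O)Nc2cccc(-c3oc4cc(-c5ccc(F)cc5)ccc4c(=O)c3O)c2)cc1` in a functional assay on MCF7 cells (Homo sapiens) for antiproliferative activity, read by CCK-8 assay, with a stated time of 72 h (a higher number here means a weaker inhibitor, a lower number a stronger inhibitor), gives 6250 nM. Compound 2 `COc1ccccc1C(=O)Nc1cccc(-c2oc3cc(-c4ccc(F)cc4)ccc3c(=O)c2O)c1` in this assay gives 2100 nM. Compound 3 `O=C(Nc1cccc(-c2oc3cc(-c4ccc(F)cc4)ccc3c(=O)c2O)c1)c1ccc(Br)cc1` in this assay gives 24000 nM, the highest of the three numbers: a 3.8-fold higher number from compound 1 to compound 3 (0.58 log units; beyond the scatter), and an 11-fold higher number from compound 2 to compound 3 (1.06 log units; beyond the scatter). Within the pairs measured, the step of a 3.0-fold lower number from compound 1 to compound 2 (0.47 log units; beyond the scatter) shows that where the methoxy sits on the aryl matters as well as what the substituent is.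

Compound 4 `O=C(Nc1cccc(-c2oc3cc(-c4ccc(F)cc4)ccc3c(=O)c2O)c1)c1cccc(F)c1` differs from compound 3 at one point: 3-fluorophenyl in place of 4-bromophenyl on a carbonyl carbon. Within the data shown here, the steps that bear on this are those into compound 3, the bromo in place of methoxy step from compound 1 and the aryl exchange from compound 2, both of which run toward higher numbers and end at compound 3. Among the measured compounds shown here, no measured compound carries fluorine on this aryl, and no pair shows a halogen exchange alone, so the direction of the step is uncertain. Since compound 3 holds the highest number, a move away from 4-bromophenyl is expected to give a modestly lower number, about a 2.0-fold lower number from compound 3 to compound 4 (0.30 log units; within the scatter), rather than a further rise. Compound 4 in this assay is therefore expected at roughly 12000 nM, within 4000 nM to 35000 nM.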

Compound 4, half-maximal inhibitory concentration: 5770 nM
Compound 4: middle estimate off by 2.1-fold (0.32 log units), on the high side; the range from low to high includes it.
By their numbers in this assay, from the lowest: compound 2; then compounds 4 and 1 (each within the scatter of the next); then compound 3.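

In this assay, among these compounds, the step to 3-fluorophenyl from 4-bromophenyl on the carbonyl carbon gives a 4.2-fold lower number from compound 3 to compound 4 (0.62 log units; beyond the scatter) and is the first measured change at this position that leaves a halogen on the aryl, showing that a halogen-bearing aryl need not carry the high number of compound 3. The 3-fluorophenyl and 4-methoxyphenyl groups cannot be told apart here, with a 1.1-fold lower number from compound 1 to compound 4 (0.03 log units; within the scatter) as the printed step, so two different substituents on this aryl read alike in this series. The 2-methoxyphenyl group keeps its lead, with a 2.7-fold higher number from compound 2 to compound 4 (0.44 log units; beyond the scatter) as the step, and compound 2 remains the strongest of the four, its steps to all three others lying beyond the scatter.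

No measurement on hand accounts for any of these steps. The change from compound 3 to compound 4 alters both the halogen and its place on the aryl, and the compounds shown cannot separate the two, nor do they show how an amine or a carboxylic acid on this aryl would read.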